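The compounds below may be only part of what the source reports. "The series", "measured", "known", "first", "only" and "open" are said of these compounds alone.

Compound 1 `O=c1c(-c2nn[nH]n2)c[nH]c2c(F)cccc12` is the starting point. Compound 1 gives 0.625 mg/kg in a functional assay on the whole organism (strain Sprague-Dawley) for inhibition, with Rattus norvegicus as the target; on this read-out lower numbers stand for an effect already at smaller amounts and higher numbers for an effect only at larger amounts of compound. Compound 3 `Cc1cc(F)c2[nH]cc(-c3nn[nH]n3)c(=O)c2c1` differs from it by a single change, (methyl in place of hydrogen on an aromatic carbon). Compound 3 gives 2.5 mg/kg in this assay. That change produced a 4.0-fold higher number from compound 1 to compound 3 (0.60 log units; beyond the scatter). Compound 2 `Cc1cccc2cc(C(=O)O)cnc12` is built on a different core, and the difference between the two cores is not broken down here. For compound 2 only a limit of this assay is recorded, > 50 mg/kg. One further point of reference is the limit of > 50 mg/kg in this assay, at which 1 of the 3 values shown sits. Compound 4 `Cc1ccc2cc(C(=O)O)cnc2c1C` has not yet been measured; it differs from compound 2 by methyl in place of hydrogen on an aromatic carbon. For the measured compounds named here, this is the same kind of change as the one from compound 1 to compound 3, though not the same: in compound 4 the new methyl sits ortho to a methyl group, whereas in compound 3 it sits meta to a fluoro group. Since compound 2 already stands at a limit, > 50 mg/kg, and the comparable change gave a 4.0-fold higher number from compound 1 to compound 3 (0.60 log units; beyond the scatter), the expected step is a step that the limit leaves unreadable from compound 2 to compound 4. Compound 4 is accordingly estimated at 100 mg/kg, and a limit rather than a number is likely to be recorded again.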

Compound 4, minimum effective dose: 25 mg/kg
Beside the measured number, compound 4's estimate is 4.0-fold (0.60 log units) above it; measured number inside the range.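

In this assay, the methyl change does not carry over from one core to the other in the same direction: the new step is an at least 2.0-fold lower number from compound 2 to compound 4 (0.30 log units; that floor lies within the scatter), and that size is only a floor. Set beside the earlier step, the same change gives clearly different results on the two cores: the same change on two cores in this assay, a 4.0-fold higher number (0.60 log units; beyond the scatter) from compound 1 to compound 3 and an at least 2.0-fold lower number (0.30 log units; that floor lies within the scatter) from compound 2 to compound 4, at least 8.0-fold (0.90 log units) apart, beyond the scatter of two such steps This shows that, for these compounds, the effect of adding a methyl on one core does not predict its effect on the other, but it rests on a single pair per core, the new methyl does not have the same surroundings in the two pairs, and it gives no explanation for the difference.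

On these data alone, compound 2 stands at a limit of the assay, > 50 mg/kg, so the true size of its step remains open. Also open, as far as these compounds go, is whether the difference follows the core or the place of the methyl, and how an ethyl or a methoxy group on the same aromatic carbon would read on each core.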